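The source may hold more compounds than are shown below. What is called first, only, known or untested is meant among the compounds shown, and "the series" means these compounds.

Of the compounds shown here, three built on one shared core have been measured in an assay on HeLa cells for displacement of a labelled ligand from adenosine receptor A3 (Homo sapiens), read by fluorescence polarization, with a stated time of 30 min; a lower number here means a stronger inhibitor, a higher number a weaker inhibitor. Compound 1 `COc1ccc(-c2cc(NC(=O)CCC(=O)NCC(=O)NC(C)(C)C)nc(-c3ccc(OC)cc3)n2)cc1` gives 36700 nM, compound 2 `COc1ccc(-c2cc(NC(=O)CCC(=O)NCC(=O)NC3CCCCC3)nc(-c3ccc(OC)cc3)n2)cc1` gives 74200 nM, and compound 3 `COc1ccc(-c2cc(NC(=O)CCC(=O)NCC(=O)NCc3ccccc3)nc(-c3ccc(OC)cc3)n2)cc1` gives 50800 nM. Compound 3 stands within the scatter of both others, since a 1.4-fold higher number from compound 1 to compound 3 (0.14 log units; within the scatter) and a 1.5-fold lower number from compound 2 to compound 3 (0.16 log units; within the scatter), whereas a 2.0-fold higher number from compound 1 to compound 2 (0.31 log units; beyond the scatter). Compound 4 `COc1ccc(-c2cc(NC(=O)CCC(=O)N(C)CC(=O)NC3CCCCC3)nc(-c3ccc(OC)cc3)n2)cc1` carries ((cyclohexylcarbamoyl)methyl)(methyl)amino in place of ((benzylcarbamoyl)methyl)amino on a carbonyl carbon. The cyclohexyl part of this change is the reverse of the measured step of a 1.5-fold lower number from compound 2 to compound 3 (0.16 log units; within the scatter); the methyl added on the amide-type nitrogen has no measured counterpart among these compounds. A step close to the reverse of that measured one is therefore expected, a 1.6-fold higher number from compound 3 to compound 4 (0.20 log units; within the scatter), with no basis for anything larger. Compound 4 is estimated at 80000 nM, within a range from 30000 nM to 220000 nM.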

Compound 4, inhibition constant: 52900 nM
Compound 4: middle estimate off by 1.5-fold (0.18 log units), on the high side; the range from low to high includes it.
By their numbers in this assay, from the lowest: compounds 1, 3, 4 and 2 (each within the scatter of the next, the first and the last beyond it).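

Methyl in place of hydrogen on the amide-type nitrogen is the first change at that nitrogen with a reading in this assay, and it gives a 1.4-fold lower number from compound 2 to compound 4 (0.15 log units; within the scatter) in that assay. The two wider replacements on the carbonyl carbon, a 1.0-fold higher number from compound 3 to compound 4 (0.02 log units; within the scatter) and a 1.4-fold higher number from compound 1 to compound 4 (0.16 log units; within the scatter) also lie within the scatter, so none of the three new steps goes beyond it. No measurement given here offers an explanation for these numbers.

From the compounds shown here alone, whether ethyl on that nitrogen, or an amine or a carboxylic acid in place of the cyclohexyl, would give a step beyond the scatter stays open. So does whether the methyl would read the same with tert-butyl or benzyl in place of the cyclohexyl.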